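The source may report more compounds than this note shows. Statements on the series, on what has been measured and on what is new or still open speak of the compounds shown alone.

Compound 1 `Cc1cccc(-c2nc3cc(C)ccc3c(=O)[nH]2)c1` heads the pair. In an assay on isolated protein for inhibition of DNA topoisomerase 1 (Homo sapiens), with a stated time of 30 min, tested at 100 uM (a higher number here means a stronger effect of the compound at the concentration tested, a lower number a weaker effect), compound 1 gives 100%, the highest of the two numbers recorded; compound 2 `Cc1ccc2nc(-c3cccc4ccccc34)[nH]c(=O)c2c1` gives 4.1% in this assay, far lower and beyond the scatter. Compound 3 `Cc1ccc2c(=O)[nH]c(-c3cccc(C(F)(F)F)c3)nc2c1` awaits measurement. Compound 3 differs from compound 1 by trifluoromethyl in place of methyl on an aromatic carbon, on an aromatic carbon of a six-membered aromatic ring of carbon only. Among the measured compounds shown here, no step between measured compounds isolates this change, so its size is open; a moderate decrease in this assay is expected, though a result within the scatter is possible. For compound 3 the estimate is 70%, in the range 25% to 100%. The expected step is a number 30 percentage points lower from compound 1 to compound 3 (beyond the scatter).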

Compound 3, a percentage reported as inhibition, at one concentration (the size of the read-out at that concentration, not a potency): 100%
The estimate for compound 3 lay 30 percentage points below the measured number; measured number inside the range.
By their numbers in this assay, from the lowest: compound 2; then compounds 1 and 3 (each within the scatter of the next).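

In this assay, trifluoromethyl in place of methyl on this aromatic carbon, meta to a large group, gives no change at the digits printed from compound 1 to compound 3 (within the scatter). Among the compounds shown here, this is the first single-place step at this position, and it shows that the position accepts trifluoromethyl without a loss beyond the scatter. No measurement at hand explains this outcome.

Both compounds were read at one concentration, so any difference in potency between them remains unresolved. As far as these compounds go, whether an amine or a carboxylic acid at this position would hold the read-out also remains open.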